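The compounds below may be only part of what the source reports. "The series", "measured", "known", "first", "only" and "open" are said of these compounds alone.

Compound 1 `Cc1ccc(-n2nc(-c3ccc(C(F)(F)F)cc3O)nc2-c2ccccc2O)cc1` gives 71.5% in a functional assay on PC-12 cells (Rattus norvegicus) for cytotoxicity, read by MTT assay, with stated times of 2 h and 24 h, tested at 1 uM (on this read-out lower numbers stand for a weaker effect and higher numbers for a stronger effect at the one concentration tested), and stands highest of the three numbers measured, though compound 3 `COc1ccccc1-n1nc(-c2ccc(C(F)(F)F)cc2O)nc1-c1ccccc1O` with 70.7% and compound 2 `Oc1cc(C(F)(F)F)ccc1-c1nc(-c2ccccc2O)n(-c2ccccc2F)n1` with 63.4% both lie within the scatter of it. Compound 4 `Oc1cc(C(F)(F)F)ccc1-c1nc(-c2ccccc2O)n(-c2cccc(F)c2)n1` differs from compound 1 by 3-fluorophenyl in place of 4-methylphenyl on an aromatic nitrogen. Two measured steps exchange the same group on the same nitrogen and bear directly on this one: a number 8.1 percentage points lower from compound 1 to compound 2 (within the scatter) and a number 0.8 percentage points lower from compound 1 to compound 3 (within the scatter). The comparison a number 7.3 percentage points higher from compound 2 to compound 3 (within the scatter) also stays within the scatter. On these numbers no movement beyond the scatter in this assay is expected from the new group. Compound 4 is therefore estimated at 68%, within 55% to 80%, which means an expected step of a number 3.5 percentage points lower from compound 1 to compound 4 (within the scatter).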

Compound 4, a percentage reported as activity, at one concentration (the size of the read-out at that concentration, not a potency): 67.2%
Estimate against measurement, compound 4: 0.8 percentage points above; the measured number falls inside the stated range.
By their numbers in this assay, from the lowest: compounds 2, 4, 3 and 1 (each within the scatter of the next).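

In this assay the 3-fluorophenyl group on the aromatic nitrogen does not separate from the groups seen there before, with a number 4.3 percentage points lower from compound 1 to compound 4 (within the scatter) and a number 3.5 percentage points lower from compound 3 to compound 4 (within the scatter) as the two steps from the carbon-only substituted rings. Shifting the fluorine gives a number 3.8 percentage points higher from compound 2 to compound 4 (within the scatter) and so adds no separation between the 2-fluorophenyl and 3-fluorophenyl groups. Nothing at hand explains this flat picture.

From the compounds shown here alone, whether any group on this nitrogen moves the number beyond the scatter stays open, for instance a phenyl carrying an amine or a carboxylic acid. Going by these compounds, the 2-hydroxyphenyl and trifluoromethyl parts stay unchanged throughout these compounds, so their contribution also remains open.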